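From 4-nitrophenyl to 2-nitrophenyl in compound 4

This account rests on a few compounds, and the source may have more. Where it says the series, first, only, none or still open, it means among the compounds named here.

Measured so far in a functional assay on NB-4 cells (Homo sapiens) for inhibition, read by XTT assay, with a stated time of 48 h; a higher number here means a weaker inhibitor, a lower number a stronger inhibitor
- Compound 1 `COc1ccc(C(=O)/C(=C/C2CCCCC2)COC(=O)c2ccccc2)cc1` gives 10200 nM
- Compound 2 `C=C(C(=O)c1ccc(OC)cc1)C(OC(C)=O)c1ccc([N+](=O)[O-])cc1` gives 10300 nM
- Compound 3 `C=C(C(=O)c1ccc(OC)cc1OC)C(OC(C)=O)c1ccc([N+](=O)[O-])cc1` gives 5000 nM

Compound 3 has the lowest of these three numbers, and its gaps to compound 1 and compound 2 both lie beyond the usual scatter. Compound 4 `C=C(C(=O)c1ccc(OC)cc1OC)C(OC(C)=O)c1ccccc1[N+](=O)[O-]` is still unmeasured. It differs from compound 3 in one group: 2-nitrophenyl in place of 4-nitrophenyl on a saturated chain carbon bound to a double-bonded chain carbon and an oxygen next to a carbonyl group sits on a saturated chain carbon bound to a double-bonded chain carbon and an oxygen next to a carbonyl group. Within the data shown here, the only measured step, a 2.1-fold lower number from compound 2 to compound 3 (0.31 log units; beyond the scatter), is modest and comes from a methoxy in place of hydrogen, a different change. Among the measured compounds shown here, no measured step shows what this swap does, so no direction can be read from the data. The expected step, a 1.2-fold higher number from compound 3 to compound 4 (0.08 log units; within the scatter), therefore stays within the scatter. For compound 4 the estimated value is 6000 nM, with an expected range of 2500 nM to 14000 nM for this estimate.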

Compound 4, half-maximal inhibitory concentration: 8800 nM
The estimate for compound 4 lay 1.5-fold (0.17 log units) below the measured number; measured number inside the range.
By their numbers in this assay, from the lowest: compounds 3, 4, 1 and 2 (each within the scatter of the next, the first and the last beyond it).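

Putting 2-nitrophenyl in place of 4-nitrophenyl on this saturated chain carbon gives a 1.8-fold higher number from compound 3 to compound 4 (0.25 log units; within the scatter), so the swap does not separate compound 3 from compound 4. Among these compounds, this is the first view of the nitrophenyl group, as the earlier step changed only a methoxy on the other aromatic ring. Nothing available accounts for this result.

The compounds shown leave open what a phenyl ring bearing an amine or a carboxylic acid in place of the nitro group would give on this carbon. They also leave open whether the same swap gives a similar step without the extra methoxy of compound 3.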